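Fluoro to Chloro at One Aromatic Carbon

The source may hold more compounds than are shown below. What is called first, only, known or untested is meant among the compounds shown, and "the series" means these compounds.

In a functional assay on NCI-H460 cells (Homo sapiens) for cytotoxicity, read by sulforhodamine B assay, with a stated time of 3 days (a lower number here means a stronger inhibitor, a higher number a weaker inhibitor), compound 1 (`O=Cc1cn(Cc2ccc(Cl)cc2Cl)c2ccccc12`) gives 100 nM and compound 2 (`O=Cc1cn(Cc2ccc(Br)c(Br)c2)c2ccccc12`) gives 63 nM. Compound 3 (`O=Cc1cn(Cc2ccc(Cl)cc2)c2ccc(F)cc12`) gives 290 nM, the highest of the three numbers, which makes it the weakest inhibitor so far, with both gaps beyond the usual scatter.

Compound 4 (`O=Cc1cn(Cc2ccc(Cl)cc2)c2ccc(Cl)cc12`) differs from compound 3 in one place, with chloro in place of fluoro on an aromatic carbon. Among the compounds with values here, no measured pair of compounds shows this swap on its own, so the size of the change can only be judged indirectly. The one hint is weak: compound 1 at 100 nM and compound 2 at 63 nM both carry chlorine or bromine and both stand lower, yet each also differs from compound 3 in other ways.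

A modest fall in the number is therefore expected, a 1.9-fold lower number from compound 3 to compound 4 (0.29 log units; within the scatter), a step about as large as the usual scatter. For compound 4 the estimated value is 150 nM, with an expected range of 60 nM to 400 nM.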

Compound 4, half-maximal inhibitory concentration: 400 nM
Beside the measured number, compound 4's estimate is 2.7-fold (0.43 log units) below it; low and high end bracket the measured number.
By their numbers in this assay, from the lowest: compounds 2 and 1 (each within the scatter of the next); then compounds 3 and 4 (each within the scatter of the next).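

Within the data shown here, this is the first direct reading of the swap: in this assay, chloro in place of fluoro on this aromatic carbon gives a 1.4-fold higher number from compound 3 to compound 4 (0.14 log units; within the scatter). Compound 3 and compound 4 therefore cannot be told apart, and on this carbon the two atoms are interchangeable as far as these numbers can show, though that rests on this one pair alone. Nothing measured here explains why the two compounds read alike.

Going by these compounds, whether a quite different group on the same carbon, such as a methoxy group or an amine, would shift the number remains open. A single pair also cannot say whether the same swap would read alike on another aromatic carbon or with a different group on the rest of the molecule.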